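Series notes: from compound 1 toward compound 4

A few compounds are considered here, and "the series" means these few. Any claim that something is new, unique, unknown or untested is made for them only; others in the source may bear on it.

Measured in an assay for inhibition of protein disulfide-isomerase (Homo sapiens), with a stated time of 1 h; a lower number here means a stronger inhibitor, a higher number a weaker inhibitor:
- compound 1 `Cc1ccnc(NC(c2ccc(C(F)(F)F)cc2)c2ccc3cccnc3c2O)c1` gives 26500 nM.
- compound 2 `Oc1ccc2cnccc2c1C(c1ccc(F)cc1)N1CCCCC1` gives > 100000 nM, a limit of the assay and not a number.
- compound 3 `Oc1cc2c(cc1C(c1ccc(F)cc1)N1CCCCC1)CCCC2` gives > 100000 nM, likewise a limit of the assay.

For the measured compounds named here, compound 1 thus holds the only number in this assay; the other two values sit at the limit of > 100000 nM in this assay, at which 2 of the 3 values shown sit. Going by the values given here, no two measured compounds differ in a single place, so no measured step is available. Compound 4 `Cc1ccnc(NC(c2cccc(F)c2)c2ccc3cccnc3c2O)c1` carries 3-fluorophenyl in place of 4-(trifluoromethyl)phenyl on a saturated chain carbon bound to an aromatic carbon and a nitrogen on an aromatic ring. Without a measured step to lean on, a modest shift toward weaker inhibition in this assay is expected, possibly no larger than the scatter. The expected step is a 1.5-fold higher number from compound 1 to compound 4 (0.18 log units; within the scatter). Compound 4 is estimated at 40000 nM, within 12000 nM to 130000 nM.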

Compound 4, half-maximal inhibitory concentration: 350 nM
Compound 4: the middle estimate sits 110-fold (2.06 log units) above what was measured, outside the stated range (below it).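

Replacing 4-(trifluoromethyl)phenyl with 3-fluorophenyl on this saturated chain carbon gives a 76-fold lower number from compound 1 to compound 4 (1.88 log units; beyond the scatter) in this assay, so the group at this position strongly affects the reading. The earlier compounds offered one number and otherwise limits, and no step at all, so this is the first measured change in the series: the limit of > 100000 nM in this assay, at which 2 of the 4 values shown sit.

This single step changes both the substituent and where it sits on the phenyl ring, and the two cannot be separated here. As far as these compounds go, it remains open how a plain phenyl or a 3-chlorophenyl at this position would read.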